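A Double Bond Redrawn in a Cytotoxicity Read-Out

The compounds below may be only part of what the source reports. "The series", "measured", "known", "first", "only" and "open" are said of these compounds alone.

In a functional assay on HT-29 cells (Homo sapiens) for cytotoxicity (on this read-out lower numbers stand for an effect already at smaller amounts and higher numbers for an effect only at larger amounts of compound), compound 1 `C=C1OC(=O)/C(=C/CCCC/C=C\CCCCCCCCC)[C@@H]1O` gives 1.9 ug/mL and compound 2 `C=CCCCCCCCCC/C=C1/C(=O)OC(=C)[C@H]1O` gives 2.92 ug/mL on the same scale, so compound 2 stands within the usual scatter of compound 1. Compound 3 `C=CCCCCCCCCC/C=C1\C(=O)OC(=C)[C@H]1O` is still unmeasured. Against compound 2 it shows this change: the two compounds have the same atoms and bonds and differ only in configuration as drawn: 1 of 2 stereo elements differ; a double bond is drawn E in compound 2 and Z in compound 3 with a double bond drawn E in compound 2 and Z in compound 3. For the measured compounds named here, no measured pair shows what such a change does, so in this assay no step beyond the scatter is expected, in either direction. The expected result is a 1.0-fold lower number from compound 2 to compound 3 (0.02 log units; within the scatter) as an estimate. For compound 3 the estimated value is 2.8 ug/mL within an expected range of 1.2 ug/mL to 6.5 ug/mL in this read-out.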

Compound 3, concentration for half-maximal effect: 3.26 ug/mL
For compound 3 the middle estimate is 1.2-fold (0.07 log units) below the measured one, within the range that was stated.
By their numbers in this assay, from the lowest: compounds 1, 2 and 3 (each within the scatter of the next).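

For the compounds shown here, compounds 2 and 3 form the first measured pair for this redrawn double bond, and in this assay the step is a 1.1-fold higher number from compound 2 to compound 3 (0.05 log units; within the scatter). At this position, on this chain, the drawn geometry of the double bond therefore does not separate the two compounds on this read-out. The comparison is a clean one, since nothing else changes: the fact that compounds 2 and 3 differ only in the configuration as drawn

What the compounds shown leave open is whether the same redrawing would remain this quiet in a compound carrying a longer chain or a carboxylic acid. They also cannot say whether it would hold in any other cell assay.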